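Isopropyl on the side chain of compound 2

This account rests on a few compounds, and the source may have more. Where it says the series, first, only, none or still open, it means among the compounds named here.

Measured in a functional assay on L1210 cells (Mus musculus) for inhibition; a higher number here means a weaker inhibitor, a lower number a stronger inhibitor:
compound 1 `COC1=CC(=O)c2ncnc(NCCCN(C)C)c2C1=O` gives 0.501 ug/mL
compound 2 `COC(=O)CNc1ncnc2c1C(=O)C(OC)=CC2=O` gives 1.2 ug/mL
compound 3 `CCCC(=O)OCCNc1ncnc2c1C(=O)C(OC)=CC2=O` gives 0.85 ug/mL

Compound 2 stands apart from compound 1 only: a 2.4-fold higher number from compound 1 to compound 2 (0.38 log units; beyond the scatter) sits against a 1.4-fold lower number from compound 2 to compound 3 (0.15 log units; within the scatter) on the other side. Compound 4 `COC(=O)C(Nc1ncnc2c1C(=O)C(OC)=CC2=O)C(C)C` puts isopropyl in place of hydrogen on a saturated chain carbon bound to a carbonyl carbon and a nitrogen on an aromatic ring. Going by the values given here, no measured compound carries a group at that carbon, so there is no direct guide. The side-chain swaps stayed small, with a 1.7-fold higher number from compound 1 to compound 3 (0.23 log units; within the scatter) as the remaining step, so no large move is expected. An expected no change at the digits printed from compound 2 to compound 4 (within the scatter) is the working estimate. Compound 4 is estimated at 1.2 ug/mL in this assay with an expected range of 0.45 ug/mL to 3 ug/mL for now.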

Compound 4, half-maximal inhibitory concentration: 0.825 ug/mL
The estimate for compound 4 lay 1.5-fold (0.16 log units) above the measured number; measured number inside the range.
By their numbers in this assay, from the lowest: compounds 1, 4, 3 and 2 (each within the scatter of the next, the first and the last beyond it).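

In this assay, the saturated chain carbon bound to a carbonyl carbon and a nitrogen on an aromatic ring tolerates isopropyl in place of hydrogen, with a 1.5-fold lower number from compound 2 to compound 4 (0.16 log units; within the scatter). Going by these compounds alone, this is the first reading at that carbon, and it shows that a branched group of 3 heavy atoms there leaves the number within the scatter of compound 2. No supporting evidence bears on this result. Still open, as far as these compounds go, is whether a phenyl group or a longer chain at this carbon would be tolerated as well. Also open, from the compounds shown here alone, is how a free carboxylic acid in place of the methoxycarbonyl would read.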